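This account rests on a few compounds, and the source may have more. Where it says the series, first, only, none or still open, it means among the compounds named here.

Measured compounds in a functional assay on A549 cells (Homo sapiens) for antiproliferative activity, read by sulforhodamine B assay, with a stated time of 72 h; on this read-out higher numbers stand for weaker inhibition of growth and lower numbers for stronger inhibition of growth:
Compound 1, `Cc1cc(=O)oc2cc(SCc3cccnc3)ccc12`: > 35200 nM, a limit.
Compound 2, `CCc1cc(=O)c2ccc(OC)c(CBr)c2o1`: > 33600 nM, a limit.
Compound 3, `COc1ccc2c(=O)cc(C(C)Br)oc2c1CBr`: > 26500 nM, a limit.

Compound 3 therefore stands only at a limit in this assay, as do the other two values shown (the limit of > 26500 nM in this assay, at which 1 of the 3 values shown sits), (the limit of > 33600 nM in this assay, at which 1 of the 3 values shown sits), (the limit of > 35200 nM in this assay, at which 1 of the 3 values shown sits). For the measured compounds named here, the one single-point step among the measured compounds, a step that the two limits leave unreadable from compound 2 to compound 3, is unreadable, since both ends are limits.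

Compound 4, `CC(C)Oc1ccc2c(=O)cc(C(C)Br)oc2c1CBr`, differs from compound 3 by isopropyl in place of methyl on an oxygen on an aromatic ring. Going by the values given here, no measured step touches this change, and the only step in the set cannot be read, so there is nothing here to support a move in either direction beyond the scatter. The expectation rests on compound 3 sitting at > 26500 nM and on the series showing no measurable growth inhibition so far.

Compound 4 is therefore expected at 40000 nM, with a range of 10000 nM to 150000 nM, and most likely reported again as a limit. The expected step is a step that the limit leaves unreadable from compound 3 to compound 4, no change beyond the scatter.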

Compound 4, concentration for 50% growth inhibition: 12800 nM
Estimate against measurement, compound 4: 3.1-fold (0.49 log units) above; measured number inside the range.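

In this assay, for the compounds shown here, the change from methoxy to isopropoxy gives an at least 2.0-fold lower number from compound 3 to compound 4 (0.31 log units; beyond the scatter) and yields the only value shown that is not a limit. Going by these compounds alone, the oxygen on an aromatic ring is thus a place where a change moves the read-out, something the earlier compounds could not show: the step from compound 2 to compound 3 cannot be read, as both of its ends are limits. Nothing measured here accounts for the step from methoxy to isopropoxy. Still open, on these data alone, is whether the step follows chain length or branching, which a propoxy group, a longer chain or an amine-bearing chain at this oxygen would help to separate. Also open, as far as these compounds go, is whether the bromo on the saturated chain carbon contributes once isopropoxy is in place.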